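The compounds below may be only part of what the source reports. "The series", "measured", "known", "first", "only" and "open" are said of these compounds alone.

Measured so far in an assay on HEK293 cells for displacement of a labelled ligand from melanin-concentrating hormone receptor 1 (Homo sapiens); on this read-out lower numbers stand for stronger inhibition and higher numbers for weaker inhibition:

compound 1 `O=C(NC1CCN(Cc2ccn(-c3ccc(C(F)(F)F)cc3)c2)CC1)NS(=O)(=O)c1ccc(F)cc1` gives 617 nM
compound 2 `O=C(NC1CCN(Cc2ccn(-c3ccc(C(F)(F)F)cc3)c2)CC1)N1CCn2cccc2C1c1ccccc1` gives 10 nM
compound 3 `O=C(NC[C@H]1CCCC[C@H]1O)NC1CCN(Cc2ccn(-c3ccc(C(F)(F)F)cc3)c2)CC1` gives 63 nM

Compound 1 stands with the highest number of the three. Its nearest neighbour is compound 3, and its furthest is compound 2, which carries a fused bicyclic amine on the carbonyl carbon; the gap between compound 1 and compound 2 is not a single change, so only the two values are compared here.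

Among the compounds with values here, the one single-change step on record from compound 1 is a 9.8-fold lower number from compound 1 to compound 3 (0.99 log units; beyond the scatter). Replacing the ((4-fluorophenyl)sulfonyl) group with a saturated ring bearing a hydroxyl group thus lowered the number well beyond the scatter.

Compound 4 `O=C(NC1CCN(Cc2ccn(-c3ccc(C(F)(F)F)cc3)c2)CC1)N1CCCC(CO)C1` differs from compound 1 as follows: 3-(hydroxymethyl)piperidin-1-yl in place of ((4-fluorophenyl)sulfonyl)amino on a carbonyl carbon. Like compound 3, it trades the sulfonyl group for a saturated six-membered ring carrying a hydroxyl, now as 3-(hydroxymethyl)piperidin-1-yl attached directly to the carbonyl carbon. Within the data shown here, the step of a 9.8-fold lower number from compound 1 to compound 3 (0.99 log units; beyond the scatter) is the only measured step that bears on this change, so a lower number of comparable size is expected, with broad uncertainty because the ring is attached differently.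

For compound 4 the expected value is 80 nM (range 25 nM to 250 nM), which corresponds to an expected 7.7-fold lower number from compound 1 to compound 4 (0.89 log units; beyond the scatter).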

Compound 4, half-maximal inhibitory concentration: 23 nM
For compound 4 the middle estimate is 3.5-fold (0.54 log units) above the measured one; the measured number lies below the stated range.
By their numbers in this assay, from the lowest: compound 2; then compound 4; then compound 3; then compound 1.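

With the hydroxyl-bearing group on the same carbonyl carbon in this assay, 3-(hydroxymethyl)piperidin-1-yl in place of ((4-fluorophenyl)sulfonyl)amino gives the larger gain from the sulfonyl compound (a 27-fold lower number from compound 1 to compound 4 (1.43 log units; beyond the scatter)). The two hydroxyl-bearing groups are not interchangeable at this place, since the change from ((2-hydroxycyclohexyl)methyl)amino to 3-(hydroxymethyl)piperidin-1-yl still moves the number beyond the scatter (a 2.7-fold lower number from compound 3 to compound 4 (0.44 log units; beyond the scatter)). No supporting measurement accounts for either step.

Still open, on these data alone, is whether the hydroxymethyl contributes at all, which unsubstituted piperidin-1-yl would test, and whether methoxymethyl, aminomethyl or a carboxylic acid at the same ring carbon would serve equally. The two mirror-image forms of compound 4 also remain unresolved, as its structure carries no stated configuration at the ring carbon bearing the hydroxymethyl.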